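Replacing (4-fluorophenyl)sulfonyl with benzoyl on a shared core

The compounds below may be only part of what the source reports. "The series", "measured", "known", "first", "only" and "open" are said of these compounds alone.

Three measured compounds share one core and differ only at the end of their chain. Compound 1 `O=S(=O)(NCCCNc1nccc(-c2c(-c3cccc(F)c3)nc3sccn23)n1)c1ccc(Br)cc1` gives 9400 nM in a functional assay on SK-MEL-28 cells (Homo sapiens) for cytotoxicity, read by MTT assay; a lower number here means a stronger inhibitor, a higher number a weaker inhibitor. Compound 2 `COc1ccc(S(=O)(=O)NCCCNc2nccc(-c3c(-c4cccc(F)c4)nc4sccn34)n2)cc1` gives 8980 nM in this assay, and compound 3 `O=S(=O)(NCCNc1nccc(-c2c(-c3cccc(F)c3)nc3sccn23)n1)c1ccc(F)cc1` gives 9450 nM in this assay. Compound 3 has the highest of the three numbers, yet each of the other two sits within the usual scatter of it, so the three cannot be told apart on these data. Compound 4 `O=C(NCCNc1nccc(-c2c(-c3cccc(F)c3)nc3sccn23)n1)c1ccccc1` is the next step: benzoyl in place of (4-fluorophenyl)sulfonyl on an amine nitrogen. Among the measured compounds shown here, two measured steps touch the same chain-end region, though neither exchanges the sulfonyl for a carbonyl: a 1.0-fold lower number from compound 1 to compound 2 (0.02 log units; within the scatter) and a 1.0-fold higher number from compound 1 to compound 3 (0.00 log units; within the scatter). For the measured compounds named here, both fall within the scatter, so changes at this end have so far shifted nothing, and no measured step shows what the sulfonyl-to-carbonyl exchange itself does. The expected step is a 1.0-fold higher number from compound 3 to compound 4 (0.00 log units; within the scatter), which is no change beyond the scatter. Compound 4 is estimated at 9500 nM in this assay, with a range from 4000 nM to 22000 nM.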

Compound 4, half-maximal inhibitory concentration: 17000 nM
Compound 4: the middle estimate sits 1.8-fold (0.25 log units) below what was measured; the measured number falls inside the stated range.
By their numbers in this assay, from the lowest: compounds 2, 1, 3 and 4 (each within the scatter of the next).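

Exchanging the sulfonyl for a carbonyl on this amine nitrogen can now be read directly in this assay, and the step stays within the scatter (a 1.8-fold higher number from compound 3 to compound 4 (0.26 log units; within the scatter)). A second comparison, which also changes the chain and the ring substituent at once, likewise stays within the scatter (a 1.8-fold higher number from compound 1 to compound 4 (0.26 log units; within the scatter)), so every change at this chain end shown so far has left the number indistinguishable from the others. No supporting measurement bears on why this end of the molecule makes so little difference here.

As far as these compounds go, whether any group at this position can move the number beyond the scatter remains open. A free amine, a urea or a carboxylic acid at the chain end would test this, as would a benzoyl carrying a fluorine on its ring.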